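Tetrahalophthalimides: N-Aryl Variation and Whole-Organism Inhibition

The source may report more compounds than this note shows. Statements on the series, on what has been measured and on what is new or still open speak of the compounds shown alone.

Compound 2 `O=C1c2c(Br)c(Br)c(Br)c(Br)c2C(=O)N1c1ccncc1` gives 13% in a functional assay on the whole organism (serum, strain Swiss albino) with Rattus norvegicus as the target, read by spectrophotometry, with a stated time of 14 days, at a dose of 10 mg/kg by the oral route; on this read-out higher numbers stand for more inhibition at the one dose given (going by the name of the read-out) and lower numbers for less inhibition. Among the three measured compounds it stands second highest: compound 3 `O=C1c2c(Cl)c(Cl)c(Cl)c(Cl)c2C(=O)N1c1ncccn1` gives 3%, a number that lies within the scatter of compound 2, while compound 1 `O=C1c2c(Br)c(Br)c(Br)c(Br)c2C(=O)N1Cc1ccccn1` gives 54%, well beyond it. Going by the values given here, the one measured step that changes the group on the amide-type nitrogen, a number 41 percentage points lower from compound 1 to compound 2 (beyond the scatter), was large. Compound 4 `O=C1c2c(Br)c(Br)c(Br)c(Br)c2C(=O)N1c1ncccn1` differs from compound 2 by pyrimidin-2-yl in place of pyridin-4-yl on an amide-type nitrogen in a ring. Among the compounds with values here, no measured step covers this exact exchange; compound 3 carries the entering pyrimidin-2-yl on a chloro core and sits close to compound 2, so no move beyond the scatter is expected. Compound 4 is therefore estimated at 8%, range 0% to 25%, an expected step of a number 5 percentage points lower from compound 2 to compound 4 (within the scatter).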

Compound 4, a percentage reported as inhibition, in the whole organism at one dose (the size of the read-out at that dose, not a potency): 19%
Compound 4: middle estimate off by 11 percentage points, on the low side, and the stated range covers the measured number.
By their numbers in this assay, from the lowest: compounds 3, 2 and 4 (each within the scatter of the next, the first and the last beyond it); then compound 1.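

Pyrimidin-2-yl in place of pyridin-4-yl on an amide-type nitrogen in a ring gives a number 6 percentage points higher from compound 2 to compound 4 (within the scatter) in this assay, so this exchange does not separate the two aromatic rings. Pyrimidin-2-yl in place of (pyridin-2-yl)methyl gives a number 35 percentage points lower from compound 1 to compound 4 (beyond the scatter), a second large step that leaves compound 1 apart from both compounds with these rings. Nothing available explains either step.

Still open, on these data alone, is whether the (pyridin-2-yl)methyl result depends on the carbon link or on the pyridin-2-yl ring. Plain pyridin-2-yl, (pyridin-4-yl)methyl and a longer 2-(pyridin-2-yl)ethyl chain on the same nitrogen would address this.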